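The source may report more compounds than this note shows. Statements on the series, on what has been measured and on what is new or still open speak of the compounds shown alone.

Three compounds have been examined. Compound 1 `O=C(Nc1ccc(S(=O)(=O)NCc2ccccc2)cc1)c1ccc(Cl)cc1Cl` and compound 2 `COc1ccc(NS(=O)(=O)c2ccc(NC(=O)c3ccc(Cl)cc3Cl)cc2)cc1` carry a benzyl and a 4-methoxyphenyl group on the sulfonamide nitrogen; in a functional assay on HEK293 cells for agonist activity at probable G-protein coupled receptor 27 (Homo sapiens), read by a luciferase reporter and beta-arrestin recruitment, with a stated time of 10 min (on this read-out lower numbers stand for smaller maximal responses and higher numbers for larger maximal responses), compound 1 returns "not determined" (no result reported), and compound 2 likewise returns "not determined" (no result reported). Going by the values given here, compound 3 `O=C(Nc1ccc(S(=O)(=O)Nc2cccc(Cl)c2)cc1)c1ccc(Cl)cc1Cl` is therefore the only member of the set with a number: in this assay compound 3 reaches 40%, so it stands alone and cannot be ranked against the other two.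

Compound 4 `O=C(Nc1ccc(S(=O)(=O)Nc2ccccc2Cl)cc1)c1ccc(Cl)cc1Cl` is the next compound to be tested. The change from compound 3 is 2-chlorophenyl in place of 3-chlorophenyl on a sulfonamide nitrogen, a rearrangement that keeps the atoms and alters only the way they are joined. No pair of measured compounds in this series shows what such a change does, so there is no shown step to lean on. With the chlorine moved within the same ring and the sulfonamide nitrogen untouched, the step expected in this assay is small, in either direction, and most likely not beyond the usual scatter of the maximal response.

On that basis compound 4 is estimated to reach 37% in this assay, in a range from 12% to 68%. The expected step from compound 3 to compound 4 is therefore a number 3 percentage points lower from compound 3 to compound 4 (within the scatter).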

Compound 4, largest response reached (Emax), in percent of the reference or control that the assay uses: 53%
Compound 4: middle estimate off by 16 percentage points, on the low side, and the stated range covers the measured number.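

In this assay, going by these compounds alone, the exchange of 3-chlorophenyl for 2-chlorophenyl on a sulfonamide nitrogen gives a number 13 percentage points higher from compound 3 to compound 4 (beyond the scatter) and is the first step that can be read at all. The two groups hold the same heavy atoms and the same counts of donors and acceptors, so for this one pair the maximal response differs with where the chlorine stands on the ring and not with which atoms are present. Nothing measured alongside this step accounts for it, and its cause stays unknown.

Compound 1 and compound 2 offer no number to set beside these two, so the steps to their benzyl and 4-methoxyphenyl groups cannot be read. As far as these compounds go, it also remains open how the maximal response would change with a cyclohexyl group, a pyridyl ring or a carboxylic acid on the sulfonamide nitrogen, and whether the gain seen with 2-chlorophenyl would hold for anything other than chlorine.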